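The source may hold more compounds than are shown below. What is called first, only, known or untested is meant among the compounds shown, and "the series" means these compounds.

Measured compounds:
- compound 1, `CN1CCN(c2nc(Cl)nc3c2ncn3Cc2ccc(C(=O)Nc3ccccc3N)cc2)CC1`, in a functional assay on NCI-H460 cells (Homo sapiens) for antiproliferative activity, read by CCK-8 assay, with a stated time of 72 h, tested at 2 uM (a lower number here means a weaker effect, a higher number a stronger effect of the compound at the concentration tested), gives 13.5%
- compound 2, `CCCCn1cnc2c(Nc3ccccc3)nc(NCOCc3ccc(/C=C/C(=O)Nc4ccccc4N)cc3)nc21`, in this assay gives 23.1%
- compound 3, `CCCCn1cnc2c(Nc3cccc(Cl)c3)nc(NCOCc3ccc(/C=C/C(=O)Nc4ccccc4N)cc3)nc21`, in this assay gives 25.7%

Compound 1 stands lowest of the three numbers in this assay. Its nearest neighbour is compound 2, a gap within the scatter; its furthest is compound 3, a gap beyond the scatter.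

Compound 4, `Cc1ccc(Nc2nc(Cl)nc3c2ncn3Cc2ccc(C(=O)Nc3ccccc3N)cc2)cc1`, differs from compound 1 in one place: (4-methylphenyl)amino in place of 4-methylpiperazin-1-yl on an aromatic carbon.

Among the measured compounds shown here, the only measured step, a number 2.6 percentage points higher from compound 2 to compound 3 (within the scatter), concerns a different change on a different pair and so does not bear on this exchange. For the measured compounds named here, no measured pair in the set swaps the group at this position, so the size and direction of the step cannot be read from the data. Compound 1 sits at the low end, which leaves room above; a modest movement in either direction is plausible and nothing beyond the scatter is expected with confidence. Compound 4 is therefore estimated at 20%, with a range of 5% to 40%, corresponding to an expected a number 6.5 percentage points higher from compound 1 to compound 4 (within the scatter).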

Compound 4, a percentage reported as inhibition, at one concentration (the size of the read-out at that concentration, not a potency): 67.3%
The estimate for compound 4 lay 47.3 percentage points below the measured number; measured number outside the range, above it.
By their numbers in this assay, from the lowest: compounds 1, 2 and 3 (each within the scatter of the next, the first and the last beyond it); then compound 4.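

In this assay, among the compounds shown here, this position on the shared core strongly affects the read-out: (4-methylphenyl)amino in place of 4-methylpiperazin-1-yl gives a number 53.8 percentage points higher from compound 1 to compound 4 (beyond the scatter), whereas the only earlier step, a number 2.6 percentage points higher from compound 2 to compound 3 (within the scatter), concerned a chloro group on a different pair. The exchange changes several things at once, replacing a non-aromatic ring with two hetero atoms by an aromatic ring of carbon only and bringing in the amino hydrogen-bond donor, so this single step cannot separate their contributions. No evidence on hand accounts for the size of this step.

On these data alone, whether the aromatic ring or the amino link matters more remains open, and a cyclohexylamino group or a phenyl group on the same aromatic carbon would help separate the two. As far as these compounds go, the role of the methyl group also remains open, and phenylamino or 4-methoxyphenylamino at this position would address it.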